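Naphthalen-1-yl in place of 4-fluorophenyl

The source may report more compounds than this note shows. Statements on the series, on what has been measured and on what is new or still open speak of the compounds shown alone.

In a functional assay on cells (Neutrophil, Homo sapiens) for inhibition, with a stated time of 10 min (on this read-out higher numbers stand for weaker inhibition and lower numbers for stronger inhibition), compound 1 (`CCOC(=O)c1cnn2c1N(C(=O)Nc1cccc(F)c1)C(c1ccccc1)C2`) gives 111 nM. Compound 2 (`CCOC(=O)c1cnn2c1N(C(=O)Nc1ccc(F)cc1)C(c1ccccc1)C2`) gives > 1000 nM, which is a limit of the assay and not a number. Compound 3 (`CCOC(=O)c1cnn2c1N(C(=O)Nc1cccc3ccccc13)C(c1ccccc1)C2`) carries naphthalen-1-yl in place of 4-fluorophenyl on an amide-type nitrogen. Among the measured compounds shown here, the one measured step at this nitrogen, an at least 9.0-fold higher number from compound 1 to compound 2 (0.95 log units; beyond the scatter), lies beyond the scatter, so the group there can move the number strongly. For the measured compounds named here, no measured step involves naphthalen-1-yl. The expected move in this assay is modest and toward a lower number: an at least 2.0-fold lower number from compound 2 to compound 3 (0.30 log units; that floor lies within the scatter). Compound 3 is estimated at 500 nM, with an expected range of 80 nM to 3000 nM.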

Compound 3, half-maximal inhibitory concentration: 206 nM
The estimate for compound 3 lay 2.4-fold (0.39 log units) above the measured number; measured number inside the range.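

In this assay, the amide-type nitrogen tolerates a group other than a fluorophenyl: naphthalen-1-yl restores activity lost with 4-fluorophenyl (an at least 4.8-fold lower number from compound 2 to compound 3 (0.68 log units; beyond the scatter)). Set against 3-fluorophenyl, naphthalen-1-yl cannot be told apart (a 1.9-fold higher number from compound 1 to compound 3 (0.27 log units; within the scatter)), so the added aromatic ring is accommodated here without a clear gain or loss. Compound 2 stands at a limit and not at a number, so the size of the first step is only a floor: the limit of > 1000 nM in this assay, at which 1 of the 3 values shown sits.

Open, going by these compounds, is how naphthalen-2-yl would read at this nitrogen. Also open, on these data alone, is whether an amine or a carboxylic acid on the phenyl ring would hold the number.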